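Returning to an Aryl Amide: Expecting Compound 4

The compounds below may be only part of what the source reports. "The series", "measured", "known", "first", "only" and "open" are said of these compounds alone.

Compound 3 `COc1ccc2c(=O)c(/C=C/C(=O)NCc3ccc(F)cc3)coc2c1` carries a 4-fluorobenzyl group on its amide nitrogen. In a functional assay on A549 cells (Homo sapiens) for inhibition, read by MTT assay, with a stated time of 48 h (a higher number here means a weaker inhibitor, a lower number a stronger inhibitor), compound 3 gives only a limit of the assay, > 100000 nM. That limit is the one at which a single value among the three measured compounds sits (the limit of > 100000 nM in this assay, at which 1 of the 3 values shown sits). The two compounds with true numbers are compound 1 `COc1ccc2c(=O)c(/C=C/C(=O)Nc3ccc(C)cc3)coc2c1`, which gives 17500 nM in this assay, and compound 2 `COc1ccc2c(=O)c(/C=C/C(=O)Nc3ccccc3)coc2c1`, which gives 51000 nM.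

Compound 4 `CCOc1ccc(NC(=O)/C=C/c2coc3cc(OC)ccc3c2=O)cc1` differs from compound 3 in one place: 4-ethoxyphenyl in place of 4-fluorobenzyl on an amide-type nitrogen. Among the compounds with values here, two measured steps bear on this change, an at least 5.7-fold higher number from compound 1 to compound 3 (0.75 log units; beyond the scatter) and an at least 1.9-fold higher number from compound 2 to compound 3 (0.29 log units; that floor lies within the scatter); both move from an aryl group on that nitrogen to the 4-fluorobenzyl group, and both run toward weaker inhibition. Compound 4 moves back to an aryl group, 4-ethoxyphenyl, which resembles the 4-methylphenyl of compound 1. A step toward stronger inhibition is therefore expected, an at least 5.0-fold lower number from compound 3 to compound 4 (0.69 log units; beyond the scatter). The estimate for compound 4 is 20000 nM, with a range from 6000 nM to 70000 nM.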

Compound 4, half-maximal inhibitory concentration: > 100000 nM
Compound 4: a limit, no number (the forecaster's own chance of this, stated with the estimate: 10%); at least 5.0-fold (0.69 log units) between middle value and limit.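

The aryl group on the amide-type nitrogen does not by itself give a true number in this assay: compound 4, with its 4-ethoxyphenyl group, reaches only a limit of this assay. The group on the aromatic carbon matters, since ethoxy in place of methyl gives an at least 5.7-fold higher number from compound 1 to compound 4 (0.75 log units; beyond the scatter), while ethoxy in place of hydrogen gives an at least 1.9-fold higher number from compound 2 to compound 4 (0.29 log units; that floor lies within the scatter). The step from compound 3 to compound 4 joins two limits and cannot be read, and 4-fluorobenzyl and 4-ethoxyphenyl now share the same ceiling: the limit of > 100000 nM in this assay, at which 2 of the 4 values shown sit.

On these data alone, how far compound 4 lies beyond its limit remains open. Also open, as far as these compounds go, is whether ethyl, hydroxyl or an amine on that aromatic carbon would keep a true number, and ethyl would show whether the oxygen of ethoxy or the longer chain counts.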